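A few compounds are considered here, and "the series" means these few. Any claim that something is new, unique, unknown or untested is made for them only; others in the source may bear on it.

Of the compounds shown here, three have been tested in a functional assay on the whole organism (Tail, strain ICR) with Mus musculus as the target, in the tail flick test, with a stated time of 150 min, at a dose of 25 umol/kg by the oral route; on this read-out higher numbers stand for a stronger effect at the one dose given and lower numbers for a weaker effect. Compound 1 `O=C(CN(c1nc(Cl)nc2[nH]cnc12)C1CC1)N[C@@H](CO)C(=O)OCc1ccccc1` gives 27.9% in this assay. For the measured compounds named here, compound 2 `C[C@@H](O)[C@H](NC(=O)CN(c1nc(Cl)nc2[nH]cnc12)C1CC1)C(=O)OCc1ccccc1` gives 12.8% in this assay, and the single step between them, a number 15.1 percentage points lower from compound 1 to compound 2 (beyond the scatter), is the only one-place change measured so far. Compound 3 `CC[C@H](C)[C@H](NC(=O)CN(c1ncnc2c1ncn2C1CCCCO1)C1CC1)C(=O)OCc1ccccc1` gives 16.4% in this assay, which places it second of the three numbers: it lies within the scatter of compound 2 and beyond the scatter below compound 1.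

Compound 4 `C[C@H](NC(=O)CN(c1ncnc2c1ncn2C1CCCCO1)C1CC1)C(=O)OCc1ccccc1` has not yet been measured. It differs from compound 3 in one place: methyl in place of sec-butyl on a saturated chain carbon bound to an amide-type nitrogen and a carbonyl carbon. Going by the values given here, no measured step bears directly on this change, since the step from compound 1 to compound 2 touches a different position, and its size is of no clear use here. With no direct guide, the expectation for a number 1.4 percentage points lower from compound 3 to compound 4 (within the scatter) is a step within the scatter, in no particular direction. Compound 4 is therefore expected to give about 15% in this assay, within a range from 5% to 28%.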

Compound 4, a percentage reported as activity, at one dose (the size of the read-out at that dose, not a potency): 6.01%
For compound 4 the middle estimate is 9 percentage points above the measured one, and the stated range covers the measured number.
By their numbers in this assay, from the lowest: compounds 4, 2 and 3 (each within the scatter of the next, the first and the last beyond it); then compound 1.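

In this assay, for the compounds shown here, the change from sec-butyl to methyl, on the saturated chain carbon bound to an amide-type nitrogen and a carbonyl carbon, gives a number 10.4 percentage points lower from compound 3 to compound 4 (beyond the scatter) and so shows that this position, which no earlier step touched, responds to the group placed on it. Here the methyl group, with one carbon against the four of sec-butyl, goes with the lower number, though a single pair sets no trend. Nothing available explains this drop.

From the compounds shown here alone, whether an intermediate chain such as ethyl, or a carboxylic acid or an amine on this carbon, would give a number between these two or outside them remains open. Also open, going by these compounds, is whether the same change would have a similar effect on the core of compound 1.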